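The source may report more compounds than this note shows. Statements on the series, on what has been measured and on what is new or still open speak of the compounds shown alone.

Measured so far in an assay on HL-60 cells for agonist activity at vitamin D3 receptor (Homo sapiens), read by microscopy, with a stated time of 96 h; on this read-out lower numbers stand for an effect already at smaller amounts and higher numbers for an effect only at larger amounts of compound:
compound 1, `CCn1c(C(=O)NCCCN(C)C)ccc1C(CC)(CC)c1ccc(OCC(O)C(C)(C)C)c(C)c1`, gives 37 nM.
compound 2, `CCOC(=O)c1ccc(OC(=O)c2ccc(C(CC)(CC)c3ccc(OCC(O)C(C)(C)C)c(C)c3)n2CC)cc1`, gives only the limit > 50000 nM.

On the numbers shown, compound 2 stands at the assay limit; no number is known for it, and the limit of > 50000 nM in this assay, at which 1 of the 2 values shown sits, is where it sits. Among the compounds with values here, the one measured step is an at least 1300-fold higher number from compound 1 to compound 2 (3.13 log units; beyond the scatter), the exchange of the amide for the aryl ester on the carbonyl carbon. Compound 3, `CCn1c(C(=O)Oc2ccc(CCO)cc2)ccc1C(CC)(CC)c1ccc(OCC(O)C(C)(C)C)c(C)c1`, keeps that aryl ester and changes only the substituent on its ring: 2-hydroxyethyl in place of ethoxycarbonyl on an aromatic carbon. Within the data shown here, no measured step bears directly on this exchange; the only step known runs from an amide to an ester and moves the number to the limit. With the ester kept, compound 3 is expected to remain weak in this assay, and the step of an at least 1.2-fold lower number from compound 2 to compound 3 (0.09 log units; that floor lies within the scatter) is expected to be small or not resolvable beyond the scatter. Compound 3 is estimated at 40000 nM, within 5000 nM to 200000 nM, with a fair chance that only a limit is reported again.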

Compound 3, half-maximal effective concentration: 5100 nM
For compound 3 the middle estimate is 7.8-fold (0.89 log units) above the measured one; the range from low to high includes it.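

In this assay, 2-hydroxyethyl in place of ethoxycarbonyl on the aromatic carbon para to a large group gives an at least 9.8-fold lower number from compound 2 to compound 3 (0.99 log units; beyond the scatter), so the aryl ester as such does not hold the series at the limit, and the substituent on its ring moves the number. As far as these compounds go, compound 2 has only a limit and no number, so the true size of this step stays open: the limit of > 50000 nM in this assay, at which 1 of the 3 values shown sits. Even so, the gain does not restore the level of the amide, as replacing the (3-(dimethylamino)propyl)amino group with the 4-(2-hydroxyethyl)phenoxy group gives a 140-fold higher number from compound 1 to compound 3 (2.14 log units; beyond the scatter).

The compounds shown do not separate the effect of adding the hydroxyl of the 2-hydroxyethyl group from that of removing ethoxycarbonyl, and a plain ethyl group, a carboxylic acid or a 3-hydroxypropyl chain at this place would help to tell these apart. Also open, from the compounds shown here alone, is whether an amine on the same aromatic ring, such as aminomethyl or 2-(dimethylamino)ethyl, would bring an ester closer to compound 1.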